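A few compounds are considered here, and "the series" means these few. Any claim that something is new, unique, unknown or untested is made for them only; others in the source may bear on it.

Compound 2 `CCOC(=O)Cn1ncc2c(Nc3ccc(NC(=O)c4ccccc4)cc3)ncnc21` was tested in a functional assay on cells (Homo sapiens) for inhibition, read by MTT assay, with a stated time of 72 h; on this read-out higher numbers stand for weaker inhibition and lower numbers for stronger inhibition. The value for compound 2 is a limit, > 100 ug/mL. Its two nearest relatives also give only limits. Compound 1 `CCOC(=O)Cn1ncc2c(Nc3ccc(NS(=O)(=O)c4ccccc4)cc3)ncnc21` gives a limit, > 100 ug/mL. Compound 3 `CCOC(=O)Cn1ncc2c(Nc3ccc(NC(C)=O)cc3)ncnc21` gives a limit, > 64 ug/mL. The steps that join these three, a step that the two limits leave unreadable from compound 1 to compound 2, a step that the two limits leave unreadable from compound 1 to compound 3 and a step that the two limits leave unreadable from compound 2 to compound 3, cannot be sized, as the limit of > 100 ug/mL in this assay, at which 2 of the 3 values shown sit, and the limit of > 64 ug/mL in this assay, at which 1 of the 3 values shown sits, make plain. Compound 4 `O=C(O)Cn1ncc2c(Nc3ccc(NC(=O)c4ccccc4)cc3)ncnc21` differs from compound 2 by hydrogen in place of ethyl on an oxygen next to a carbonyl group. For the measured compounds named here, no measured step covers this change, and none of the three measured steps can be read, so no shift beyond the scatter is expected for a step that the limit leaves unreadable from compound 2 to compound 4. Compound 4 is therefore expected to give 150 ug/mL, between 50 ug/mL and 500 ug/mL, most likely again only as a limit.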

Compound 4, half-maximal inhibitory concentration: > 100 ug/mL
Compound 4: only a limit was reported (the forecaster's own chance of this, stated with the estimate: 85%); the middle value does not contradict the limit.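

Compound 2 and compound 4 both give only a limit in this assay, and no size can be read for the step between them. The compounds shown leave open how strongly any of them inhibits, and whether hydrogen in place of ethyl changes that.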